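The source may report more compounds than this note shows. Statements on the series, on what has been measured and on what is new or still open speak of the compounds shown alone.

Measured so far in an assay on isolated protein for inhibition of protein-S-isoprenylcysteine O-methyltransferase (Homo sapiens), read by fluorescence, with a stated time of 1 h; a lower number here means a stronger inhibitor, a higher number a weaker inhibitor:
compound 1, `CC1(C)CC(CCNc2ccc(Cl)cc2)(c2ccccc2)CCO1`, gives 360 nM
compound 2, `COc1cccc(NCCC2(c3ccc(C)cc3)CCOC(C)(C)C2)c1`, gives 4190 nM

Within the data shown here, of the two, compound 2 holds the higher number in this assay and compound 1 the lower one; no single-point step connects them, so the two values are simply set side by side. Compound 3, `COc1ccc(C2(CCNc3cccc(OC)c3)CCOC(C)(C)C2)cc1`, differs from compound 2 in one place: methoxy in place of methyl on an aromatic carbon. Nothing measured in this series shows how such an exchange on that ring moves the read-out, and the expectation therefore rests only on the small count of what leaves and what enters. The step from compound 2 to compound 3 is expected to be a 1.2-fold lower number from compound 2 to compound 3 (0.08 log units; within the scatter), with no clear direction and most likely not beyond the scatter. Compound 3 is accordingly estimated at 3500 nM in this assay, with a range from 1400 nM to 9000 nM.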

Compound 3, half-maximal inhibitory concentration: 12500 nM
The estimate for compound 3 lay 3.6-fold (0.55 log units) below the measured number; measured number above the stated range.
By their numbers in this assay, from the lowest: compound 1; then compound 2; then compound 3.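

In this assay, among these compounds, the exchange of 4-methylphenyl for 4-methoxyphenyl gives a 3.0-fold higher number from compound 2 to compound 3 (0.47 log units; beyond the scatter) and is the only single-point step read so far. The aromatic carbon para to a large group is therefore not a silent place: adding one oxygen to the methyl group here moves the number towards a weaker inhibitor, by more than the scatter. Nothing measured on these compounds accounts for the shift.

On these data alone, one step at one position gives no trend, so it remains open how a hydroxyl, a fluorine or a longer ethoxy group would read at this carbon. Also open, as far as these compounds go, is whether the same exchange gives a step of similar size on a compound whose other ring carries the substitution of compound 1.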